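The source may hold more compounds than are shown below. What is called first, only, known or untested is meant among the compounds shown, and "the series" means these compounds.

Compound 2 `c1c[nH]c(-c2ccccc2OCC2=NCCN2)c1` gives 104% in a functional assay for activation of Alpha-1B adrenergic receptor (Homo sapiens), read by calcium flux (a higher number here means a larger maximal response, a lower number a smaller maximal response), and stands next to compound 1 `c1csc(-c2ccccc2OCC2=NCCN2)c1`, which in this assay gives 112%, the two numbers lying within the scatter of each other. For the measured compounds named here, the only measured step, a number 8 percentage points lower from compound 1 to compound 2 (within the scatter), exchanged one five-membered ring for another and changed little. Compound 3 `c1ccc(-c2ccoc2)c(OCC2=NCCN2)c1` carries a change of the same kind: furan-3-yl in place of 1H-pyrrol-2-yl on an aromatic carbon. That earlier step, a number 8 percentage points lower from compound 1 to compound 2 (within the scatter), stayed within the scatter, so no step beyond the scatter is expected in this assay. Compound 3 is therefore estimated at 104%, with a range from 90% to 118%, the expected step being no change at the digits printed from compound 2 to compound 3 (within the scatter).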

Compound 3, largest response reached (reported as maximum), in percent of the reference or control that the assay uses: 111%
Compound 3: middle estimate off by 7 percentage points, on the low side; low and high end bracket the measured number.
By their numbers in this assay, from the lowest: compounds 2, 3 and 1 (each within the scatter of the next).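

In this assay furan-3-yl in place of 1H-pyrrol-2-yl gives a number 7 percentage points higher from compound 2 to compound 3 (within the scatter) and furan-3-yl in place of thiophen-2-yl gives a number 1 percentage points lower from compound 1 to compound 3 (within the scatter), so this place on the aromatic ring tolerates a third five-membered aromatic ring without a step beyond the scatter. The hydrogen-bond donor of 1H-pyrrol-2-yl can thus be absent and a hydrogen-bond acceptor present, and attachment can be through the 3-yl carbon. Nothing measured here explains why the response holds across these rings. On these data alone, all three compounds carry a five-membered aromatic ring at this place, so whether a phenyl ring, an amine or a carboxylic acid there would keep the maximal response stays open.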